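The source may hold more compounds than are shown below. What is called first, only, known or untested is meant among the compounds shown, and "the series" means these compounds.

Three compounds of the series carry the same shared core and an unsubstituted phenyl group on it: compound 1 `Cc1nc(N)c(C#N)c(N[C@@H](C)c2cc3ccc(F)cn3c(=O)c2-c2ccccc2)n1`, compound 2 `C[C@H](Nc1nc(N)nc(N)c1C#N)c1cc(=O)n2cc(F)ccc2c1-c1ccccc1` and compound 3 `C[C@H](Nc1ncnc(N)c1C#N)c1cc(=O)n2cc(F)ccc2c1-c1ccccc1`. In an ADME assay on microsomes from liver (Rattus norvegicus), read by LC-MS, using NADPH, with a stated time of 30 min, tested at 1 uM (a higher number here means that more of the compound is left, a lower number that less of the compound is left), compound 1 gives "not determined" (no result reported) and compound 2 gives "not determined" (no result reported), so neither provides a number. Among the compounds with values here, compound 3 is the only member with a number: in this assay compound 3 gives 74%. Within the data shown here, no step between two measured compounds can be read from this set, and nothing here shows how a change on the phenyl group moves the remaining fraction.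

Compound 4 `C[C@H](Nc1ncnc(N)c1C#N)c1cc(=O)n2cc(F)ccc2c1-c1cccc(F)c1` differs from compound 3 in one place: fluoro in place of hydrogen on an aromatic carbon. Among the measured compounds shown here, with no measured step to lean on, the expectation for this change is a step no larger than the usual scatter, in either direction. The estimated step is a number 2 percentage points higher from compound 3 to compound 4 (within the scatter). Compound 4 is expected to give about 76%, within a range from 60% to 90%.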

Compound 4, percent of the compound remaining: 79%
The estimate for compound 4 lay 3 percentage points below the measured number; the range from low to high includes it.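

On a six-membered aromatic ring of carbon only, meta to a large group, fluoro in place of hydrogen leaves the fraction remaining in this assay within the scatter (a number 5 percentage points higher from compound 3 to compound 4 (within the scatter)). Within the data shown here, this is the only readable step so far, and it shows that phenyl to 3-fluorophenyl at this place gives no change beyond repeated measurement in this assay, with both compounds retaining most of the parent. No data shown here speak to why the result falls as it does.

On these data alone, whether methoxy, an amine or a carboxylic acid at this place would shift the remaining fraction beyond the scatter stays open, as does fluoro elsewhere on the phenyl group. Steps involving compound 1 and compound 2 cannot be read.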